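Amide Variation on a Benzoxazole Thyroid Receptor Series

The compounds below may be only part of what the source reports. "The series", "measured", "known", "first", "only" and "open" are said of these compounds alone.

Compound 1, `CCCN(CC1CCOC1)C(=O)c1cc(Cl)c2oc(NCc3cccc(Cl)c3)nc2c1`, in an assay on isolated protein for inhibition of thyroid hormone receptor beta (Homo sapiens), read by fluorescence, with a stated time of 30 min (a higher number here means a weaker inhibitor, a lower number a stronger inhibitor), gives 71 nM.
Compound 2, `COc1cc(C(=O)N2CCC(C)(C)C2)cc2nc(NCc3cccc(Cl)c3)oc12`, in this assay gives 40 nM.

Within the data shown here, of the two compounds measured so far, compound 2 has the lower number in this assay, yet its nearest neighbour, compound 1, sits close enough that the two values fall within the usual scatter, so neither can be called the stronger inhibitor. Both share the same core and the same chlorobenzylamino substituent; they differ in the amide and in the ring substituent next to the carbonyl.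

Compound 3, `COc1cc(C(=O)N2CC(C)C(O)CC2C2CC2)cc2nc(NCc3cccc(Cl)c3)oc12`, has not yet been measured. It differs from compound 2 in one place: 2-cyclopropyl-4-hydroxy-5-methylpiperidin-1-yl in place of 3,3-dimethylpyrrolidin-1-yl on a carbonyl carbon. The incoming piperidine is larger than the pyrrolidine it replaces and brings a hydroxyl group along with a cyclopropyl and a methyl. Among the measured compounds shown here, with no measured pair showing how such an amide exchange moves this assay, no step beyond the scatter is expected in either direction. Compound 3 is therefore estimated at 50 nM, within 15 nM to 170 nM, and the expected step of a 1.3-fold higher number from compound 2 to compound 3 (0.10 log units; within the scatter) is essentially flat.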

Compound 3, half-maximal inhibitory concentration: 8 nM
Compound 3: middle estimate off by 6.3-fold (0.80 log units), on the high side; measured number outside the range, below it.
By their numbers in this assay, from the lowest: compound 3; then compounds 2 and 1 (each within the scatter of the next).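

In this assay the amide on this carbonyl carbon proves not to be indifferent: exchanging 3,3-dimethylpyrrolidin-1-yl for 2-cyclopropyl-4-hydroxy-5-methylpiperidin-1-yl gives a 5.0-fold lower number from compound 2 to compound 3 (0.70 log units; beyond the scatter) and so moves the number beyond the scatter. This is the only change in one place among the compounds shown, and it is the first sign that the choice of amide alone can shift this assay, with the larger piperidine, carrying one hydrogen-bond donor and one hydrogen-bond acceptor, accepted here and giving the lower number. Nothing available explains the direction or the size of this step.

The step rests on a single pair in which the ring size, the hydroxyl, the cyclopropyl and the methyl all change together, so it cannot be assigned to any one of them. On these data alone, a plain piperidin-1-yl, a 4-hydroxypiperidin-1-yl without the other two groups, or a morpholin-4-yl would each bear on that question, and the effect of the three-dimensional arrangement of the substituted piperidine also remains open.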